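Lengthening the Alkyl Chain on the Ring Amine Nitrogen

The source may hold more compounds than are shown below. What is called first, only, known or untested is meant among the compounds shown, and "the series" means these compounds.

Of the compounds shown here, two sharing one core have been measured. Compound 1 `CS(=O)(=O)N(CC1CC1)c1ccccc1N1CCN(C(=O)[C@H](CC(=O)N2CCNCC2)Cc2ccc(Cl)cc2)CC1` carries a free hydrogen on the amine nitrogen in its ring, and in an assay on isolated protein for binding affinity to Melanocortin receptor 4 (Homo sapiens) (a lower number here means a stronger inhibitor, a higher number a weaker inhibitor), compound 1 gives 220 nM. Compound 2 `CCN1CCN(C(=O)C[C@H](Cc2ccc(Cl)cc2)C(=O)N2CCN(c3ccccc3N(CC3CC3)S(C)(=O)=O)CC2)CC1` bears an ethyl on that nitrogen, and in this assay compound 2 gives 9.5 nM. The step of a 23-fold lower number from compound 1 to compound 2 (1.36 log units; beyond the scatter) is the only one available, and it places compound 2 at the lowest of the two numbers shown, with compound 1 the nearest neighbour.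

Compound 3 `CC(C)CCN1CCN(C(=O)C[C@H](Cc2ccc(Cl)cc2)C(=O)N2CCN(c3ccccc3N(CC3CC3)S(C)(=O)=O)CC2)CC1` continues along the same chain: the change is isopropyl in place of hydrogen on a saturated chain carbon, two bonds along the chain from an amine nitrogen in a ring, so that the ethyl becomes an isopentyl. The step from compound 1 to compound 2 bears on this only indirectly, since it concerns the first alkyl added to the nitrogen rather than its extension. For the measured compounds named here, no measured step tells how a longer chain behaves here, so for this assay the expectation is a small step, perhaps none beyond the scatter, in either direction. Compound 3 is therefore estimated at 12 nM, within 3 nM to 50 nM, an expected step of a 1.3-fold higher number from compound 2 to compound 3 (0.10 log units; within the scatter).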

Compound 3, half-maximal inhibitory concentration: 4.8 nM
Beside the measured number, compound 3's estimate is 2.5-fold (0.40 log units) above it, and the stated range covers the measured number.
By their numbers in this assay, from the lowest: compounds 3 and 2 (each within the scatter of the next); then compound 1.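

Extending the ethyl of compound 2 to the isopentyl of compound 3 gives a 2.0-fold lower number from compound 2 to compound 3 (0.30 log units; within the scatter) in this assay, so at this position the two chains cannot be told apart in this assay. Measured against the free hydrogen on the amine nitrogen in the ring, the isopentyl gives a 46-fold lower number from compound 1 to compound 3 (1.66 log units; beyond the scatter), a second large step that stands with a 23-fold lower number from compound 1 to compound 2 (1.36 log units; beyond the scatter), and this shows that the large difference from the free hydrogen is not confined to the ethyl but holds for a longer, branched chain too. Nothing shown here gives a reason for any of these steps.

On these data alone, what remains open is how far the chain on this nitrogen can grow before the number moves beyond the scatter, and whether an unbranched pentyl, a benzyl, or a chain ending in an amine or a carboxylic acid would behave like the isopentyl. For the compounds shown here, with only three compounds, all on the shared core, the effect of chain length cannot be separated from that of branching, and nothing shows how the rest of the core behaves with the isopentyl in place.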